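A tetrazole in place of an oxadiazole

The source may report more compounds than this note shows. Statements on the series, on what has been measured and on what is new or still open speak of the compounds shown alone.

In an ADME assay on the whole organism for metabolic stability, with Rattus norvegicus as the target (a lower number here means that the compound disappears faster, a higher number that the compound lasts longer), compound 1 (`CC1(C)CC2(CCN(C(=O)c3ccc(C[C@@H]4CC[C@H]([C@H](O)c5ccccc5)N4)cc3)CC2)C(=O)O1`) gives 2 h and compound 2 (`O=C(c1ccc(C[C@@H]2CC[C@H]([C@H](O)c3ccccc3)N2)cc1)N1C[C@@H]2[C@H](C1)[C@H]2c1nnco1`) gives 1.4 h within the usual scatter of each other. Compound 3 (`Cn1nnc([C@H]2[C@@H]3CN(C(=O)c4ccc(C[C@@H]5CC[C@H]([C@H](O)c6ccccc6)N5)cc4)C[C@@H]32)n1`) carries 2-methyl-2H-tetrazol-5-yl in place of 1,3,4-oxadiazol-2-yl on a saturated ring carbon. Among the measured compounds shown here, no measured pair isolates such a change, so no step beyond the scatter is expected in this assay here, in either direction. The expected step is a 1.1-fold higher number from compound 2 to compound 3 (0.06 log units; within the scatter) and it stays within that scatter. For compound 3 the estimated half-life is 1.6 h with an expected range (0.8 h to 3.2 h).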

Compound 3, half-life: 3.2 h
Compound 3: the middle estimate sits 2.0-fold (0.30 log units) below what was measured; the range from low to high includes it.
By their numbers in this assay, from the lowest: compounds 2, 1 and 3 (each within the scatter of the next, the first and the last beyond it).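

On the saturated ring carbon of the three-membered ring, 2-methyl-2H-tetrazol-5-yl in place of 1,3,4-oxadiazol-2-yl gives a 2.3-fold higher number from compound 2 to compound 3 (0.36 log units; beyond the scatter) in this assay. This is the first single-place step shown, and it shows that the number at this position responds to the choice of five-membered aromatic ring. Nothing available explains the step.

A single pair cannot show whether the tetrazole ring or its methyl accounts for the step. Also open, from the compounds shown here alone, is how a carboxylic acid or a primary amine on this same carbon would compare.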